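The source may hold more compounds than are shown below. What is called first, only, known or untested is meant among the compounds shown, and "the series" means these compounds.

In an ADME assay on the whole organism (strain Sprague-Dawley) for pharmacokinetics, with Rattus norvegicus as the target, read by LC-MS, using cassette dosing, at a dose of 0.5 mg/kg by the intravenous route (a higher number here means faster removal of the compound, a lower number slower removal), the measured compounds read:

- compound 1 `C[C@@]1(c2cc(NC(=O)c3cnc(OCF)cn3)ccc2F)C=C(CF)OC(N)=N1` gives 34.4 mL/min/kg
- compound 2 `Cc1cc(C#N)cnc1C(=O)Nc1ccc(F)c([C@]2(C)C=C(CF)OC(N)=N2)c1` gives 21.8 mL/min/kg
- compound 3 `C[C@@]1(c2cc(NC(=O)c3ccc(C#N)cn3)ccc2F)C=C(CF)OC(N)=N1` gives 16.8 mL/min/kg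

Compound 3 lies within the scatter of compound 2 in this assay and clearly apart only from compound 1, through a 2.0-fold lower number from compound 1 to compound 3 (0.31 log units; beyond the scatter), a modest step. Compound 4 `COc1cc(C#N)cnc1C(=O)Nc1ccc(F)c([C@]2(C)C=C(CF)OC(N)=N2)c1` carries methoxy in place of hydrogen on an aromatic carbon, turning 5-cyanopyridin-2-yl into 5-cyano-3-methoxypyridin-2-yl. Counted out, the change is methoxy in place of hydrogen on an aromatic carbon and nothing else differs.

Within the data shown here, no measured compound carries this methoxy, so the data offer only a neighbour. Compound 2 holds 5-cyano-3-methylpyridin-2-yl, with methyl where compound 4 has methoxy, and the step of a 1.3-fold lower number from compound 2 to compound 3 (0.11 log units; within the scatter) stayed inside the scatter. The steps of a 1.6-fold lower number from compound 1 to compound 2 (0.20 log units; within the scatter) and a 2.0-fold lower number from compound 1 to compound 3 (0.31 log units; beyond the scatter) replace a whole group and say less about this change. A small substituent on this ring has so far moved the number little, so no change beyond the scatter is expected, with a slight lean toward compound 2 at 21.8 mL/min/kg in the reading. The expected step is a 1.2-fold higher number from compound 3 to compound 4 (0.08 log units; within the scatter), and it is only an estimate. For compound 4 the estimated clearance is 20 mL/min/kg, with an expected range from 11 mL/min/kg to 36 mL/min/kg in this measurement.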

Compound 4, clearance: 36.6 mL/min/kg
Estimate against measurement, compound 4: 1.8-fold (0.26 log units) below; measured number outside the range, above it.
By their numbers in this assay, from the lowest: compounds 3, 2, 1 and 4 (each within the scatter of the next, the first and the last beyond it).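

On the pyridine ring, at the carbon two atoms from the ring nitrogen, the size of the group can matter after all: in this assay, methoxy in place of hydrogen gives a 2.2-fold higher number from compound 3 to compound 4 (0.34 log units; beyond the scatter) and so leaves the scatter, a modest step, whereas the methyl of compound 2 did not. Methoxy and methyl themselves cannot be separated, as a 1.7-fold higher number from compound 2 to compound 4 (0.23 log units; within the scatter) stays within the scatter, so hydrogen, methyl and methoxy form a graded series in which only the two ends stand clearly apart. Exchanging the whole 5-(fluoromethoxy)pyrazin-2-yl group for 5-cyano-3-methoxypyridin-2-yl gives a 1.1-fold higher number from compound 1 to compound 4 (0.03 log units; within the scatter) and also stays within the scatter, so adding methoxy to compound 3 cancels the modest gain in slower removal seen from compound 1 to compound 3.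

Nothing available here bears on the reason for this rise. As far as these compounds go, whether the oxygen or the added size counts most stays open, and a hydroxyl, an ethoxy or a chlorine at the same carbon, each read in the same rat clearance measurement, would help separate the two.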